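The compounds below may be only part of what the source reports. "The series", "measured", "known", "first", "only" and "open" are said of these compounds alone.

Measured so far in an assay on NK92 cells for inhibition of interleukin-15 (Homo sapiens), read by AlphaScreen, with stated times of 30 min and 1 h; a lower number here means a stronger inhibitor, a higher number a weaker inhibitor:

compound 1, `Cn1c(Cc2nn(C)c(=O)c3ccccc23)nnc1SCC(=O)Nc1ccc(Cl)cc1Cl`: 4500 nM
compound 2, `Cn1c(Cc2nn(CCCO)c(=O)c3ccccc23)nnc1SCC(=O)Nc1ccc(Cl)cc1Cl`: 30000 nM

Going by the values given here, the single measured step is a 6.7-fold higher number from compound 1 to compound 2 (0.82 log units; beyond the scatter). Among the compounds with values here, compound 2 therefore stands at the highest of the two numbers in this assay, with compound 1 as its only neighbour, and the gap between them is beyond the scatter.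

Compound 3, `Cn1c(Cc2nn(CCC(=O)O)c(=O)c3ccccc23)nnc1SCC(=O)Nc1ccc(Cl)cc1Cl`, has not yet been measured. It differs from compound 2 by carboxy in place of hydroxymethyl on a saturated chain carbon, two bonds along the chain from an aromatic nitrogen. Within the data shown here, no measured step bears directly on this exchange: the one step available, a 6.7-fold higher number from compound 1 to compound 2 (0.82 log units; beyond the scatter), concerns the lengthening of the chain on the aromatic nitrogen rather than the group at its end, so it offers only an indirect hint that this part of the molecule is sensitive to change. With nothing more to go on, the estimate for compound 3 leans toward a number near that of compound 2, perhaps somewhat higher, but with wide uncertainty. Compound 3 is thus expected to give about 40000 nM in this assay, within a range from 10000 nM to 150000 nM. This corresponds to an expected step of a 1.3-fold higher number from compound 2 to compound 3 (0.12 log units; within the scatter), which is estimated to lie close to the edge of the scatter.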

Compound 3, half-maximal inhibitory concentration: > 30000 nM
Compound 3: only a limit was reported; the forecaster's own chance of this, stated with the estimate: 30%; the middle value is on the limit's open side.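

The reading for compound 3 is a limit and not a number: the limit of > 30000 nM in this assay, at which 1 of the 3 values shown sits. Carboxy in place of hydroxymethyl gives a number no lower from compound 2 to compound 3 (the limit leaves the size open), a step that cannot be read in size. What can be read is the comparison with the methyl-bearing compound, where carboxymethyl in place of hydrogen on a saturated chain carbon bound to an aromatic nitrogen gives an at least 6.6-fold higher number from compound 1 to compound 3 (0.82 log units; beyond the scatter). A second chain end on this nitrogen, the 2-carboxyethyl group after the 3-hydroxypropyl group, therefore also falls on the weaker side of compound 1, so among these three compounds neither chain end restores the inhibition seen with the methyl group, and no compound shown goes against this.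

Going by these compounds, it remains open whether the weakening comes from the chain itself or from the group at its end, a question that a plain propyl chain, with no oxygen at its end, would address. On these data alone, how an amine or an amide at the chain end, or a shorter or longer chain carrying the carboxylic acid, would read at this position also remains open.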